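Tetrazole substituent variation on an octylphenoxy ketone series

The source may hold more compounds than are shown below. What is called first, only, known or untested is meant among the compounds shown, and "the series" means these compounds.

Measured compounds in an assay on microsomes from brain for inhibition of Fatty-acid amide hydrolase 1 (Rattus norvegicus), read by fluorescence and HPLC, with a stated time of 60 min; a higher number here means a weaker inhibitor, a lower number a stronger inhibitor:
- compound 1 `CCCCCCCCc1ccc(OCC(=O)Cn2nnc(C)n2)cc1`: 27 nM
- compound 2 `CCCCCCCCc1ccc(OCC(=O)Cn2nnc(C(=O)O)n2)cc1`: 41 nM
- compound 3 `CCCCCCCCc1ccc(OCC(=O)Cn2nnnc2C)cc1`: 41 nM

Compound 3 sits level with compound 2 at the digits shown, and the two together give the highest numbers of the three in this assay; the gap to compound 1 is small, a 1.5-fold higher number from compound 1 to compound 3 (0.18 log units; within the scatter), and lies within the scatter. The other steps are equally modest: a 1.5-fold higher number from compound 1 to compound 2 (0.18 log units; within the scatter) and no change at the digits printed from compound 2 to compound 3 (within the scatter). None of the three substitutions at the tetrazole, nor the switch between the two tetrazole attachment modes, moved the read-out beyond the scatter.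

Compound 4 `CCCCCCCCc1ccc(OCC(=O)Cn2nnnc2SC)cc1` follows from compound 3 by methylsulfanyl in place of methyl on an aromatic carbon. Among the compounds with values here, the only measured step at the same ring position is the carboxy-for-methyl exchange, a 1.5-fold higher number from compound 1 to compound 2 (0.18 log units; within the scatter), which stayed within the scatter, albeit on the other tetrazole isomer. Within the data shown here, no step bears on a sulfur-bearing group. On that basis a step of a 1.1-fold higher number from compound 3 to compound 4 (0.04 log units; within the scatter) is expected, i.e. nothing beyond the scatter, in this assay. Compound 4 is therefore estimated at 45 nM, with a range of 20 nM to 100 nM.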

Compound 4, half-maximal inhibitory concentration: 22 nM
Compound 4: the middle estimate sits 2.0-fold (0.31 log units) above what was measured; measured number inside the range.
By their numbers in this assay, from the lowest: compounds 4, 1, 2 and 3 (each within the scatter of the next).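

In this assay, within the data shown here, the aromatic carbon between two ring nitrogen atoms accepts methylsulfanyl in place of methyl with a 1.9-fold lower number from compound 3 to compound 4 (0.27 log units; within the scatter) as the step, so the first sulfur-bearing group here, with two heavy atoms where methyl has one, stays inside the scatter. The whole-group exchanges read the same way, with a 1.9-fold lower number from compound 2 to compound 4 (0.27 log units; within the scatter) and a 1.2-fold lower number from compound 1 to compound 4 (0.09 log units; within the scatter) as their steps, which places 5-(methylsulfanyl)-1H-tetrazol-1-yl level with both 2H-tetrazol-2-yl groups within the scatter. Nothing at hand accounts for these steps or ties them to any property of the group.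

Still open, on these data alone, is whether an amine or a longer ethylsulfanyl chain on the same aromatic carbon would also stay inside the scatter. Also open, as far as these compounds go, is how methylsulfanyl reads on the 2H-tetrazol-2-yl attachment of compound 1.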